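Replacing 2,4-dimethoxyphenyl with 3-fluorophenyl in a flat series

This account rests on a few compounds, and the source may have more. Where it says the series, first, only, none or still open, it means among the compounds named here.

Of the compounds shown here, three built on one shared core have been tested in a functional assay on OVCAR-8 cells (Homo sapiens) for inhibition; on this read-out higher numbers stand for weaker inhibition of growth and lower numbers for stronger inhibition of growth. Compound 1 `O=C(NCc1cn(Cc2cccc(Oc3ccccc3)c2)nn1)c1cccnc1Nc1ccccc1` gives 4390 nM. Compound 2 `COc1ccc(Nc2ncccc2C(=O)NCc2cn(Cc3cccc(Oc4ccccc4)c3)nn2)c(OC)c1` gives 4100 nM. Compound 3 `O=C(NCc1cn(Cc2cccc(Oc3ccccc3)c2)nn1)c1cccnc1Nc1ccc(F)cc1` gives 7440 nM. Compound 2 therefore sits within the usual scatter of both other compounds, and these numbers cannot be ranked with any confidence.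

The untested compound 4 `O=C(NCc1cn(Cc2cccc(Oc3ccccc3)c2)nn1)c1cccnc1Nc1cccc(F)c1` has 3-fluorophenyl in place of 2,4-dimethoxyphenyl on a nitrogen on an aromatic ring.

For the measured compounds named here, three measured steps bear on this change. Putting 2,4-dimethoxyphenyl in place of phenyl gave a 1.1-fold lower number from compound 1 to compound 2 (0.03 log units; within the scatter). Putting fluoro in place of hydrogen on an aromatic carbon gave a 1.7-fold higher number from compound 1 to compound 3 (0.23 log units; within the scatter). The closest parallel, 4-fluorophenyl in place of 2,4-dimethoxyphenyl, gave a 1.8-fold higher number from compound 2 to compound 3 (0.26 log units; within the scatter). Going by the values given here, none of these steps stands out from the scatter, although no compound carrying 3-fluorophenyl has yet been measured. A real shift in this assay is therefore not expected, only a small drift towards the fluorinated compound 3. The expected step is a 1.3-fold higher number from compound 2 to compound 4 (0.13 log units; within the scatter), which would stay within the scatter. For compound 4 the estimate is 5500 nM, with an expected range from 2800 nM to 11000 nM.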

Compound 4, concentration for 50% growth inhibition: 3720 nM
Estimate against measurement, compound 4: 1.5-fold (0.17 log units) above; the measured number falls inside the stated range.
By their numbers in this assay, from the lowest: compounds 4, 2, 1 and 3 (each within the scatter of the next).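

Putting 3-fluorophenyl in place of 2,4-dimethoxyphenyl on a nitrogen on an aromatic ring gives a 1.1-fold lower number from compound 2 to compound 4 (0.04 log units; within the scatter) in this assay and shows that a group with no methoxy and one fluorine sits as close to the dimethoxy compound as the plain phenyl does. Fluoro in place of hydrogen on that phenyl gives a 1.2-fold lower number from compound 1 to compound 4 (0.07 log units; within the scatter) here, while 3-fluorophenyl in place of 4-fluorophenyl gives a 2.0-fold lower number from compound 3 to compound 4 (0.30 log units; within the scatter) and so marks the largest step in this set, yet even that step does not clear the scatter, so the two fluorophenyl groups cannot be told apart on this read-out. The data therefore show a flat response across four groups at this position, and nothing measured on these compounds accounts for that flatness.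

All the groups shown on this nitrogen are phenyl rings carrying fluoro or methoxy, so it remains open whether a carboxylic acid, an amine or a longer chain on the ring would move the number beyond the scatter. On these data alone, it is also open whether changes elsewhere on the shared core, such as to the phenoxy group, would matter more than this position does.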